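Compound 4: chloropyrimidinyl on the amine nitrogen

The compounds below may be only part of what the source reports. "The series", "measured", "known", "first", "only" and "open" are said of these compounds alone.

In a functional assay on VCaP cells (Homo sapiens) for antiproliferative activity, read by CCK-8 assay, with a stated time of 6 days (on this read-out higher numbers stand for weaker inhibition and lower numbers for stronger inhibition), compound 1 `C[C@@H](Cn1ccc(-c2ccc(C#N)c(Cl)c2)n1)NS(=O)(=O)c1cn(C)cn1` gives 13600 nM. Compound 2 `C[C@@H](Cn1ccc(-c2ccc(C#N)c(Cl)c2)n1)Nc1ccccc1` gives > 30000 nM, which is a limit of the assay and not a number. Compound 3 `C[C@@H](Cn1ccc(-c2ccc(C#N)c(Cl)c2)n1)Nc1ccccn1` has the entry "not determined" (no result reported), so it holds no place on the scale and cannot anchor a step.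

The change to compound 4 `C[C@@H](Cn1ccc(-c2ccc(C#N)c(Cl)c2)n1)Nc1nccc(Cl)n1` is 4-chloropyrimidin-2-yl in place of pyridin-2-yl on an amine nitrogen. Among the compounds with values here, no measured step covers this swap. The only one that bears on it is an at least 2.2-fold higher number from compound 1 to compound 2 (0.34 log units; beyond the scatter), where phenyl takes the place of (1-methyl-1H-imidazol-4-yl)sulfonyl on an amine nitrogen. That step is beyond the scatter, but its size is open-ended. Without a number for compound 3, neither the size nor the direction of the step can be stated, so only a level is expected: weak inhibition, in the region of compound 1 at 13600 nM. A limit result would not be surprising.

Compound 4 is estimated at 12000 nM, with an expected range of 2500 nM to 30000 nM.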

Compound 4, half-maximal inhibitory concentration: > 30000 nM
Compound 4 was reported as a limit (the forecaster's own chance of this, stated with the estimate: 35%); middle value at least 2.5-fold (0.39 log units) from the limit.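

In this assay, 4-chloropyrimidin-2-yl in place of (1-methyl-1H-imidazol-4-yl)sulfonyl on the amine nitrogen gives an at least 2.2-fold higher number from compound 1 to compound 4 (0.34 log units; beyond the scatter), so the drop seen with phenyl in compound 2 also appears with a six-membered aromatic ring carrying 2 hetero atoms and a chlorine. Among the compounds with a result at this position, only the sulfonyl group of compound 1 gives a number on the scale. The step between compound 2 and compound 4 cannot be read, because both results are limits of the assay: the limit of > 30000 nM in this assay, at which 2 of the 4 values shown sit.

Still open, on these data alone, is what the chlorine of 4-chloropyrimidin-2-yl contributes on its own, and whether any group on this nitrogen gives stronger inhibition than compound 1 at 13600 nM. A methanesulfonyl or acetyl group on the amine nitrogen would help separate the role of the sulfonyl link from that of the 1-methyl-1H-imidazol-4-yl part.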